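Hydroxy in Place of Chloro on the Pendant Ring

A few compounds are considered here, and "the series" means these few. Any claim that something is new, unique, unknown or untested is made for them only; others in the source may bear on it.

Compound 1, `Fc1ccc(-c2cc3c(cn2)ncn3-c2ccc(OC(F)F)cc2)cc1`: in a functional assay on HL-60 cells (Homo sapiens) for activation, read by flow cytometry, with a stated time of 4 days (on this read-out lower numbers stand for an effect already at smaller amounts and higher numbers for an effect only at larger amounts of compound), compound 1 gives 10000 nM.
Compound 2, `CCc1ccccc1-c1cc2c(cn1)ncn2-c1ccc(OC(F)F)cc1`: in this assay compound 2 gives 2900 nM.
Compound 3, `Cc1cc(Cl)ccc1-c1cc2c(cn1)ncn2-c1ccc(OC(F)F)cc1`: in this assay compound 3 gives 28 nM.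

Compound 3 stands lowest of the three: a 360-fold lower number from compound 1 to compound 3 (2.55 log units; beyond the scatter) and a 100-fold lower number from compound 2 to compound 3 (2.02 log units; beyond the scatter), both large. Compound 4, `Cc1cc(O)ccc1-c1cc2c(cn1)ncn2-c1ccc(OC(F)F)cc1`, differs from compound 3 by hydroxy in place of chloro on an aromatic carbon. Within the data shown here, no measured step changes this group alone; the two steps into compound 3 each altered the whole pendant ring, so they only show how sensitive this assay is to that ring. Among the measured compounds shown here, because compound 3 gives 28 nM and no measured compound carries a hydroxy, a loss in potency is expected, of moderate size, a 7.1-fold higher number from compound 3 to compound 4 (0.85 log units; beyond the scatter). Compound 4 is estimated at 200 nM, with a range from 40 nM to 1500 nM.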

Compound 4, half-maximal effective concentration: 890 nM
The estimate for compound 4 lay 4.5-fold (0.65 log units) below the measured number; low and high end bracket the measured number.
By their numbers in this assay, from the lowest: compound 3; then compound 4; then compound 2; then compound 1.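

In this assay, hydroxy in place of chloro, with the rest of the molecule unchanged, gives a 32-fold higher number from compound 3 to compound 4 (1.50 log units; beyond the scatter) and so shows that this single group matters greatly. The hydroxy compound still keeps part of the ring's advantage, as a 3.3-fold lower number from compound 2 to compound 4 (0.51 log units; beyond the scatter) and an 11-fold lower number from compound 1 to compound 4 (1.05 log units; beyond the scatter) show that 4-hydroxy-2-methylphenyl outperforms both earlier rings. No measurement here explains the loss.

As far as these compounds go, whether an amine or a methoxy group at this place would come closer to chloro stays open. So does how much of the potency of compound 3 depends on the methyl group.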